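The compounds below may be only part of what the source reports. "The series", "measured", "known", "first", "only" and "open" are said of these compounds alone.

Compound 1 `NC(=O)c1ncc([N+](=O)[O-])[nH]1` and compound 2 `CNC(=O)c1ncc([N+](=O)[O-])[nH]1` share one core; compound 2 carries a change (methyl in place of hydrogen on an amide-type nitrogen). In a toxicity assay on HepG2 cells (Homo sapiens) for inhibition, read by resazurin assay, with a stated time of 24 h (a higher number here means that more compound is tolerated, a lower number that less compound is tolerated), compound 1 gives > 100000 nM, which is a limit of the assay rather than a number. Compound 2 in this assay gives > 100000 nM, again a limit. The step that the two limits leave unreadable from compound 1 to compound 2 therefore cannot be sized, because of the limit of > 100000 nM in this assay, at which 3 of the 3 values shown sit.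

Compound 3 `CNC(=O)c1nc([N+](=O)[O-])cn1Cc1ccc(OC(F)(F)F)cc1` has a different core; the difference between the two cores is not broken down here. In this assay compound 3 gives > 100000 nM, once more a limit.

Compound 4 `CN(C)C(=O)c1nc([N+](=O)[O-])cn1Cc1ccc(OC(F)(F)F)cc1` is not yet measured. Among the measured compounds shown here, it differs from compound 3 by methyl in place of hydrogen on an amide-type nitrogen, the same kind of change as from compound 1 to compound 2, though here the nitrogen's other neighbours are a carbonyl carbon and a saturated chain carbon, whereas in compound 1 the only other neighbour is a carbonyl carbon. For the measured compounds named here, with every value so far at the limit, compound 4 is expected to sit at 100000 nM, estimated between 40000 nM and 300000 nM. The expected step of a number no higher from compound 3 to compound 4 (the limit leaves the size open) rests on compound 3 giving > 100000 nM.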

Compound 4, half-maximal cytotoxic concentration: > 100000 nM
Compound 4: only a limit was reported; the forecaster's own chance of this, stated with the estimate: 85%; the middle value lies on the limit itself.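

No size can be given for the step from compound 3 to compound 4, because both results are limits of the assay and not numbers: the limit of > 100000 nM in this assay, at which 4 of the 4 values shown sit.

The compounds shown leave open whether methyl in place of hydrogen on the amide-type nitrogen, or the difference between the two cores, changes how much compound is tolerated in this assay.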